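Compound 4: an Extra Nitrogen in the Linker

The source may hold more compounds than are shown below. What is called first, only, known or untested is meant among the compounds shown, and "the series" means these compounds.

Of the compounds shown here, three built on one shared core have been tested in a functional assay on Ca-Ski cells (Homo sapiens) for cytotoxicity, read by sulforhodamine B assay, with a stated time of 48 h; on this read-out higher numbers stand for weaker inhibition and lower numbers for stronger inhibition. Compound 1 `O=c1cc(-c2ccccc2)oc2cc(OCCCCNc3nc4ccccc4s3)cc(O)c12` gives 14.6 ug/mL, compound 2 `O=c1cc(-c2ccccc2)oc2cc(OCCCCNc3nc4ccc(Cl)cc4s3)cc(O)c12` gives 12.4 ug/mL, and compound 3 `O=c1cc(-c2ccccc2)oc2cc(OCCCCNc3nc4ccc(C(F)(F)F)cc4s3)cc(O)c12` gives 11.2 ug/mL. Compound 2 holds the middle number of the three, and both a 1.2-fold lower number from compound 1 to compound 2 (0.07 log units; within the scatter) and a 1.1-fold lower number from compound 2 to compound 3 (0.04 log units; within the scatter) stay inside the measurement scatter. Compound 4 `O=c1cc(-c2ccccc2)oc2cc(OCCCCNNc3nc4ccccc4s3)cc(O)c12` differs from compound 2 by (1,3-benzothiazol-2-yl)amino in place of 6-chloro-1,3-benzothiazol-2-yl on an amine nitrogen, the change sitting on an amine nitrogen whose other neighbours are a saturated chain carbon. Taking the chloro away reverses the small step of a 1.2-fold lower number from compound 1 to compound 2 (0.07 log units; within the scatter), while no measured pair shows the added nitrogen. In this assay compound 4 is therefore expected to give 14 ug/mL, between 8 ug/mL and 25 ug/mL. The expected step of a 1.1-fold higher number from compound 2 to compound 4 (0.05 log units; within the scatter) is not beyond the scatter.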

Compound 4, half-maximal inhibitory concentration: 14.6 ug/mL
Compound 4: middle estimate off by 1.0-fold (0.02 log units), on the low side, within the range that was stated.
By their numbers in this assay, from the lowest: compounds 3, 2, 1 and 4 (each within the scatter of the next).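

In this assay the added nitrogen on the amine nitrogen gives no change at the digits printed from compound 1 to compound 4 (within the scatter), so on this small set the position tolerates that one extra atom without a readable shift. The change from the chloro compound reads as a 1.2-fold higher number from compound 2 to compound 4 (0.07 log units; within the scatter), which also stays inside the usual variation between repeats. Nothing measured here explains these results. Still open, from the compounds shown here alone, is whether a larger group on the amine nitrogen, such as an acetyl or a longer chain, would move the number beyond the scatter. A methyl on the added nitrogen remains equally untested in what is shown here.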